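Hydroxy to Amino on a Shared Core: Cell Growth Inhibition

The source may hold more compounds than are shown below. What is called first, only, known or untested is meant among the compounds shown, and "the series" means these compounds.

Compound 1, `Oc1cccc(/C=C/c2cccc(O)c2)c1`: 25.9 ug/mL
Compound 2, `Oc1ccc(/C=C/c2cccc(O)c2)cc1`: 6.9 ug/mL
Compound 3, `Nc1cccc(/C=C/c2cccc(O)c2)c1`: 43 ug/mL

All three compounds were tested in a functional assay on HT-29 cells (Homo sapiens) for inhibition, read by MTT assay, with a stated time of 2 days; a higher number here means a weaker inhibitor, a lower number a stronger inhibitor. Compound 1 and compound 2 are built from the same atoms joined differently; the difference between their two cores is not broken down here. In this assay compound 2 gives the lowest number of the three, and its gaps to compound 1 and to compound 3 both lie beyond the usual scatter of repeated measurements.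

Compound 3 differs from compound 1 in a single place: amino in place of hydroxy on an aromatic carbon. This change gave a 1.7-fold higher number from compound 1 to compound 3 (0.22 log units; within the scatter), a shift small enough to sit inside the scatter, so the two compounds cannot be ranked against each other with confidence.

Compound 4, `Nc1cccc(/C=C/c2ccc(O)cc2)c1`, has not yet been measured. It differs from compound 2 by amino in place of hydroxy on an aromatic carbon. Going by the values given here, this is the same change, at the same place, as the one between compound 1 and compound 3. On that basis the step from compound 2 to compound 4 in this assay is expected to be a 1.7-fold higher number from compound 2 to compound 4 (0.24 log units; within the scatter), resting on the earlier step of a 1.7-fold higher number from compound 1 to compound 3 (0.22 log units; within the scatter). Because of 6.9 ug/mL for compound 2 as the starting point, compound 4 is estimated at 12 ug/mL, with a likely range from 5 ug/mL to 30 ug/mL.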

Compound 4, half-maximal inhibitory concentration: 51 ug/mL
For compound 4 the middle estimate is 4.3-fold (0.63 log units) below the measured one, outside the stated range (above it).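

On the core of compound 2, putting amino in place of hydroxy gave in this assay a 7.4-fold higher number from compound 2 to compound 4 (0.87 log units; beyond the scatter), a step clearly larger than repeat measurements would be expected to produce by chance. Set beside the earlier example, the same change did not carry over from one core to the other with the same size: the same change on two cores in this assay, a 1.7-fold higher number (0.22 log units; within the scatter) from compound 1 to compound 3 and a 7.4-fold higher number (0.87 log units; beyond the scatter) from compound 2 to compound 4, 4.5-fold (0.65 log units) apart, beyond the scatter of two such steps. This shows that, across these two cores, the size of the step on one core is not a safe guide to its size on the other, but it does not show why the two steps differ or how the change would behave on any further core, and two examples are too few to establish a rule for the series.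

The compounds shown leave open whether other groups at this same place, such as a methoxy group, a fluorine atom or an acetamide, would also give steps that depend on the core. They also leave open what would happen if the remaining hydroxy group, kept in both compound 3 and compound 4, were replaced by amino as well.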